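Indole carboxamide series: chain substituent versus microsomal half-life

This account rests on a few compounds, and the source may have more. Where it says the series, first, only, none or still open, it means among the compounds named here.

Measured so far, in an ADME assay on microsomes from liver (Homo sapiens) for metabolic stability, with a stated time of 30 min, tested at 1 uM; a lower number here means that the compound disappears faster, a higher number that the compound lasts longer:
compound 1, `COc1ccc2[nH]c(C(=O)N3CC(=O)N(Cc4ccccc4)[C@@H](CN4CCC(C)CC4)C3)cc2c1`: 0.267 h
compound 2, `COc1ccc2[nH]c(C(=O)N3CC(=O)N(Cc4ccccc4)[C@@H](COC(C)(C)C)C3)cc2c1`: 0.278 h
compound 3, `COc1ccc2[nH]c(C(=O)N3CC(=O)N(Cc4ccccc4)[C@@H](COc4ccc(F)cc4)C3)cc2c1`: 0.317 h

Compound 3 sits with the other two within the usual scatter: the step of a 1.2-fold higher number from compound 1 to compound 3 (0.07 log units; within the scatter) and the step of a 1.1-fold higher number from compound 2 to compound 3 (0.06 log units; within the scatter) are both small, as is the step of a 1.0-fold higher number from compound 1 to compound 2 (0.02 log units; within the scatter) between the two neighbours. Exchanging the substituent on the saturated chain carbon has so far left this assay essentially unchanged, whether that substituent is a saturated amine ring, an alkyl ether or an aryl ether.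

Compound 4, `COc1ccc2[nH]c(C(=O)N3CC(=O)N(Cc4ccccc4)[C@@H](CN4CCc5ccccc5C4)C3)cc2c1`, is the next point: 1,2,3,4-tetrahydroisoquinolin-2-yl in place of 4-fluorophenoxy on a saturated chain carbon bound to a saturated ring carbon. Going by the values given here, the change most like it is the one between compound 1 and compound 3, where a cyclic amine on the same chain carbon stood against the aryl ether, and that step was within the scatter. Compound 4 again carries a cyclic amine at this position, now fused to a benzene ring. Nothing in the measured steps points to a move beyond the scatter, in either direction.

Compound 4 is therefore expected to give about 0.28 h in this assay, between 0.17 h and 0.46 h, which means an expected step of a 1.1-fold lower number from compound 3 to compound 4 (0.05 log units; within the scatter).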

Compound 4, half-life: 0.617 h
Compound 4: middle estimate off by 2.2-fold (0.34 log units), on the low side, outside the stated range (above it).
By their numbers in this assay, from the lowest: compounds 1, 2, 3 and 4 (each within the scatter of the next, the first and the last beyond it).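

In this assay, going by these compounds alone, the substituent on a saturated chain carbon bound to a saturated ring carbon turns out to matter more than the first three compounds showed: a 2.2-fold higher number from compound 2 to compound 4 (0.35 log units; beyond the scatter) and a 2.3-fold higher number from compound 1 to compound 4 (0.36 log units; beyond the scatter) are the first steps beyond the scatter, both modest. The second of these steps joins two cyclic amines, so a cyclic amine at this place does not fix the half-life on its own, while a 1.9-fold higher number from compound 3 to compound 4 (0.29 log units; within the scatter) stays within the scatter, which leaves the 4-fluorophenoxy group as the exception to any clean split of 1,2,3,4-tetrahydroisoquinolin-2-yl from the other substituents. No supporting data are available to explain the shift.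

Open, on these data alone, is whether the benzene ring fused in 1,2,3,4-tetrahydroisoquinolin-2-yl carries the shift, which a comparison with unsubstituted piperidin-1-yl or with an open-chain N-benzyl-N-methylamine would address. Also open, as far as these compounds go, is whether a methoxy group or a fluorine on that benzene ring would move the half-life further, or return it to the level of the other compounds.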